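Trimming the phenyl from the chain: compound 4 expected

A few compounds are considered here, and "the series" means these few. Any claim that something is new, unique, unknown or untested is made for them only; others in the source may bear on it.

Measured so far in an assay for displacement of a labelled ligand from Sigma non-opioid intracellular receptor 1 (Cavia porcellus), read by scintillation counting, with a stated time of 180 min; on this read-out higher numbers stand for weaker inhibition and lower numbers for stronger inhibition:
Compound 1 `Cn1ncc2c1CCOC21CCN(N2CCC(c3ccccc3)CC2)CC1` gives 7 nM.
Compound 2 `COC1Cc2c(cnn2-c2ccccc2)C2(CCNCC2)O1` gives > 1000 nM; this is a limit of the assay, not a number, namely (the limit of > 1000 nM in this assay, at which 1 of the 3 values shown sits).
Compound 3 `COC1Cc2c(cnn2-c2ccccc2)C2(CCN(CCCCc3ccccc3)CC2)O1` gives 3.2 nM.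

Of the two numbers recorded in this assay, compound 3 holds the lower one, and compound 1 is its nearest neighbour with a higher number, beyond the scatter. Among the compounds with values here, the single step measured so far was an at least 310-fold lower number from compound 2 to compound 3 (2.49 log units; beyond the scatter), a large gain when a 4-phenylbutyl chain is attached to the ring amine nitrogen.

Compound 4 `CCCCN1CCC2(CC1)OC(OC)Cc1c2cnn1-c1ccccc1` differs from compound 3 by hydrogen in place of phenyl on a saturated chain carbon, four bonds along the chain from an amine nitrogen in a ring. This is a partial undoing of the measured step: the butyl chain stays, only its terminal phenyl is lost. Since the full change from compound 2 to compound 3 was at least the large gain shown, the expectation is that dropping the phenyl alone costs part of it, so a moderately higher number is estimated, a 16-fold higher number from compound 3 to compound 4 (1.19 log units; beyond the scatter). Compound 4 is therefore estimated at 50 nM, within a range from 10 nM to 300 nM.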

Compound 4, inhibition constant: 8 nM
The estimate for compound 4 lay 6.3-fold (0.80 log units) above the measured number; measured number outside the range, below it.
By their numbers in this assay, from the lowest: compound 3; then compounds 1 and 4 (each within the scatter of the next). At a limit, above all of these: compound 2.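

In this assay, losing the phenyl, four bonds along the chain from the ring amine nitrogen, gives a 2.5-fold higher number from compound 3 to compound 4 (0.40 log units; beyond the scatter), a modest step compared with the gain from adding the whole chain. The plain butyl group on the amine nitrogen already gives an at least 120-fold lower number from compound 2 to compound 4 (2.09 log units; beyond the scatter), a large step, so among these compounds a large gain does not require a phenyl on the chain. Compound 2 stands at a limit of the assay, not at a number: the limit of > 1000 nM in this assay, at which 1 of the 4 values shown sits.

From the compounds shown here alone, it remains open whether a shorter methyl group or a longer hexyl chain on the same nitrogen would give a similar number. Also open, going by these compounds, is how a hydroxyl group or a carboxylic acid would read in place of the phenyl.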